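Fluoro substitution on the bromopropanamide anilide series

A few compounds are considered here, and "the series" means these few. Any claim that something is new, unique, unknown or untested is made for them only; others in the source may bear on it.

Measured compounds:
compound 1 `COc1cc(NC(=O)c2cccc(NC(=O)C(C)Br)c2)cc(OC)c1OC` 670 nM
compound 2 `COc1cc(NC(=O)c2ccc(F)c(NC(=O)C(C)Br)c2)cc(OC)c1OC` 2200 nM
compound 3 `COc1ccc(NC(=O)c2cccc(NC(=O)C(C)Br)c2)cc1` 800 nM

All three were run in a functional assay on MOLT-3 cells (Homo sapiens) for antiproliferative activity; a higher number here means a weaker inhibitor, a lower number a stronger inhibitor. Compound 1 gives 670 nM, compound 3 gives 800 nM, and these two lie within the scatter of each other. The difference between the core of compound 1 and the core of compound 3 is not broken down here. Within the core of compound 1, the change fluoro in place of hydrogen on an aromatic carbon gives a 3.3-fold higher number from compound 1 to compound 2 (0.52 log units; beyond the scatter).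

Compound 4 `COc1ccc(NC(=O)c2cc(NC(=O)C(C)Br)ccc2F)cc1` is not yet measured. It differs from compound 3 by fluoro in place of hydrogen on an aromatic carbon. This is the same kind of change as from compound 1 to compound 2, but the place is not the same: in compound 2 the fluoro is ortho to the ((1-bromoethyl)carbonyl)amino group and para to a large group, whereas in compound 4 it is ortho to a large group and para to the ((1-bromoethyl)carbonyl)amino group. Resting on compound 3 at 800 nM and on the earlier step of a 3.3-fold higher number from compound 1 to compound 2 (0.52 log units; beyond the scatter), a somewhat smaller step is expected, a 2.3-fold higher number from compound 3 to compound 4 (0.35 log units; beyond the scatter), since the place differs. Compound 4 is expected to give 1800 nM, estimated between 700 nM and 4500 nM.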

Compound 4, half-maximal inhibitory concentration: 250 nM
Estimate against measurement, compound 4: 7.2-fold (0.86 log units) above; the measured number lies below the stated range.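

In this assay, fluoro in place of hydrogen on an aromatic carbon gives a 3.2-fold lower number from compound 3 to compound 4 (0.51 log units; beyond the scatter), so the direction of this change does not carry over between the two cores: the same change on two cores in this assay, a 3.3-fold higher number (0.52 log units; beyond the scatter) from compound 1 to compound 2 and a 3.2-fold lower number (0.51 log units; beyond the scatter) from compound 3 to compound 4, 11-fold (1.02 log units) apart, beyond the scatter of two such steps

The two steps differ in the core and also in the place of the fluoro, which in compound 4 is ortho to a large group and para to a ((1-bromoethyl)carbonyl)amino group. These data therefore do not separate the role of the core from that of the place, and two steps set no rule for the series.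

Still open, on these data alone, is how fluoro at each place behaves on the other core. Also open, as far as these compounds go, is whether chloro or methyl at the place it holds in compound 4 gives a step like that of fluoro.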